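The compounds below may be only part of what the source reports. "The series", "measured", "known", "first", "only" and "open" are said of these compounds alone.

In a functional assay on PC-3 cells (Homo sapiens) for inhibition, read by MTT assay, with stated times of 18 h and 4 h (a lower number here means a stronger inhibitor, a higher number a weaker inhibitor), compound 2 (`CCCCCCOP(=O)(O)OCCSC(=S)N1CCCCC1`) gives > 100000 nM as a limit of the assay and not a number. Going by the values given here, compound 1 (`CCCCCCCCCCOP(=O)(O)OCCSC(=S)N1CCCCC1`) gives 62500 nM in this assay and provides the only true number so far. Among the compounds with values here, the one measured step that bears on the next change is an at least 1.6-fold higher number from compound 1 to compound 2 (0.20 log units; that floor lies within the scatter) with hydrogen in place of butyl on the chain. The change to compound 3 (`CCCCCCCCCCCCCCCCOP(=O)(O)OCCSC(=S)N1CCCCC1`) is decyl in place of hydrogen on a saturated chain carbon, six bonds along the chain from an oxygen on an unsaturated carbon with decyl in place of hydrogen on a saturated chain carbon, six bonds along the chain from an oxygen on an unsaturated carbon. Going by compound 1 at 62500 nM a longer chain is expected to give a lower number in this assay. A single step whose floor lies within the scatter is thin support for this. The expected step is an at least 4.0-fold lower number from compound 2 to compound 3 (0.60 log units; beyond the scatter) towards stronger inhibition. The estimate for compound 3 is 25000 nM with an expected range of 8000 nM to 80000 nM across repeat measurements.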

Compound 3, half-maximal inhibitory concentration: 34300 nM
Compound 3: the middle estimate sits 1.4-fold (0.14 log units) below what was measured, within the range that was stated.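

In this assay compound 2 gives > 100000 nM, which is a limit of the assay and not a number, so any step from it can be read only as a floor: the limit of > 100000 nM in this assay, at which 1 of the 3 values shown sits.

Even so, decyl in place of hydrogen on this chain carbon gives an at least 2.9-fold lower number from compound 2 to compound 3 (0.46 log units; beyond the scatter), and this is the first step shown that clears the scatter, so lengthening the chain here does register in the assay. The further hexyl in place of hydrogen gives a 1.8-fold lower number from compound 1 to compound 3 (0.26 log units; within the scatter), which lies within the scatter, so compound 1 and compound 3 cannot be told apart.

A longer chain still could show whether the number moves any further. A chain ending in a carboxylic acid or an amine could show whether this position responds to anything other than added carbon.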